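The source may report more compounds than this note shows. Statements on the series, on what has been measured and on what is new or still open speak of the compounds shown alone.

Compound 1 `C(#Cc1ncnc2c1ncn2C1CCOCC1)c1ccccc1` bears a phenylethynyl group on its core, and in a functional assay on K562 cells (Homo sapiens) for inhibition, read by thymidine incorporation, with a stated time of 48 h, tested at 10 ug/mL (a higher number here means more inhibition at the concentration tested (going by the name of the read-out), a lower number less inhibition), compound 1 gives 100%. Compound 2 `Clc1nc2c(C#Cc3ccccc3)ncnc2n1C1CCOCC1` differs from it by chloro in place of hydrogen on an aromatic carbon; in this assay compound 2 gives 85%, so that a number 15 percentage points lower from compound 1 to compound 2 (beyond the scatter). Compound 3 `C(=C/c1ncnc2c1ncn2Cc1ccccc1)\c1ccccc1` has a core whose difference from the core of compound 1 is not broken down here; in this assay compound 3 gives 93%, within the scatter of both compound 1 and compound 2. Compound 4 `Clc1nc(/C=C/c2ccccc2)c2ncn(Cc3ccccc3)c2n1` differs from compound 3 by chloro in place of hydrogen on an aromatic carbon. This is the same kind of change as from compound 1 to compound 2, but not the same: there the chlorine entered a five-membered aromatic ring with 2 nitrogen, next to the ring atom that bears an oxan-4-yl group, whereas here it enters a six-membered aromatic ring with 2 nitrogen, meta to a 2-phenylethenyl group. A step of similar size, a number 9 percentage points lower from compound 3 to compound 4 (within the scatter), is expected because a number 15 percentage points lower from compound 1 to compound 2 (beyond the scatter) was modest. Compound 4 is therefore estimated at 84% in this assay, between 68% and 97%.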

Compound 4, a percentage reported as inhibition, at one concentration (the size of the read-out at that concentration, not a potency): 99%
Beside the measured number, compound 4's estimate is 15 percentage points below it; measured number outside the range, above it.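

In this assay, chloro in place of hydrogen on an aromatic carbon gives a number 6 percentage points higher from compound 3 to compound 4 (within the scatter). The change therefore does not carry from one core to the other as a fixed step: the same change on two cores in this assay, a number 15 percentage points lower (beyond the scatter) from compound 1 to compound 2 and a number 6 percentage points higher (within the scatter) from compound 3 to compound 4, 21 percentage points apart, beyond the scatter of two such steps. This does not show why the two steps differ, since the chlorine enters a different ring in each pair and the cores differ elsewhere too, and one pair per core cannot separate these differences.

The compounds shown leave open how an amine or a methoxy group would behave in place of the chloro. They also leave open what the same change would do on a further core.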